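This account rests on a few compounds, and the source may have more. Where it says the series, first, only, none or still open, it means among the compounds named here.

In an ADME assay on HEp-2 cells (Homo sapiens) for cytotoxicity, read by trypan blue exclusion, with a stated time of 24 h (a higher number here means that more compound is tolerated, a lower number that less compound is tolerated), compound 2 `C/C(=N\N=C1/SCC(=O)N1Cc1cccc(Cl)c1)c1cccs1` gives (21 ug/mL), which lies within the scatter of compound 3 `C/C(=N/N=C1\SCC(=O)N1Cc1ccc(F)cc1)c1ccccn1` at (16 ug/mL) and clear of compound 1 `C/C(=N\N=C1/SCC(=O)N1Cc1cccc(F)c1)c1cccs1` at (6 ug/mL). Compound 4 `C/C(=N\N=C1/SCC(=O)N1Cc1cccc(Cl)c1)c1ccccn1` carries pyridin-2-yl in place of thiophen-2-yl on a carbon with a double bond to nitrogen. Among the measured compounds shown here, no measured step covers this exchange. For the measured compounds named here, the only measured step is modest (a 3.5-fold higher number from compound 1 to compound 2 (0.54 log units; beyond the scatter)), but it is a chloro in place of fluoro on an aromatic carbon, so it bears on the change only indirectly. Going by the values given here, compound 3 is the one measured compound with pyridin-2-yl, and its value of (16 ug/mL) shows no drop to the level of compound 1 (6 ug/mL), although it differs from compound 1 in more than one place. No shift beyond the scatter is therefore expected in this assay for this exchange. The expected size is an estimated (a 1.2-fold higher number from compound 2 to compound 4 (0.08 log units; within the scatter)). For compound 4 the estimated value is 25 ug/mL with an expected range from 10 ug/mL to 60 ug/mL (end of estimate).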

Compound 4, half-maximal cytotoxic concentration: 21 ug/mL
Estimate against measurement, compound 4: 1.2-fold (0.08 log units) above; the range from low to high includes it.
By their numbers in this assay, from the lowest: compound 1; then compounds 3, 2 and 4 (each within the scatter of the next).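

In working terms, the carbon with a double bond to nitrogen now has a direct single-place comparison in this assay: pyridin-2-yl in place of thiophen-2-yl, with the rest of the structure unchanged, gives (no change at the digits printed from compound 2 to compound 4 (within the scatter)). The earlier compounds shown here offered no pair differing only at this place, so the exchange could be read only indirectly; here, the five-membered and six-membered aromatic rings can be exchanged without a shift beyond the scatter, at least with the chloro group of compound 2 in place. No measurement on these compounds gives a reason for this result.

From the compounds shown here alone, whether the exchange reads the same with fluoro in place of chloro remains open. Also open, going by these compounds, is how a phenyl ring or an open chain such as butyl would read at this carbon.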